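The source may hold more compounds than are shown below. What is called first, only, known or untested is meant among the compounds shown, and "the series" means these compounds.

Measured compounds:
compound 1 `COc1cc(/C=C/C(=O)Nc2ccccc2)ccc1OCCCN1CCCC1` — 1.57
compound 2 `CCN(CC)CCCCOc1ccc(/C=C/C(=O)Nc2ccccc2)cc1OC` — 1.59
compound 3 `COc1cc(/C=C/C(=O)Nc2ccccc2)ccc1OCCCCN1CCCCC1` — 1.61

In a physicochemical assay for lipophilicity, using the shake flask method, measured as octanol-water partition, at pH 7.4 (a higher number here means a more lipophilic compound, a lower number a more polar compound), compound 1 gives the lowest of the three numbers, though its neighbours sit within the scatter: the change a number 0.02 log units higher from compound 1 to compound 2 (within the scatter) and the change a number 0.04 log units higher from compound 1 to compound 3 (within the scatter) are both too small to read as real. Between the other two, a number 0.02 log units higher from compound 2 to compound 3 (within the scatter) is likewise within the scatter. All three measured steps swap one amine for another at the far end of the same chain and leave the rest of the molecule untouched.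

Compound 4 `COc1cc(/C=C/C(=O)Nc2ccccc2)ccc1O` is unmeasured. It differs from compound 1 by hydrogen in place of 3-(pyrrolidin-1-yl)propyl on an oxygen on an aromatic ring. Within the data shown here, none of the measured steps bears on this change: each of them replaced one amine with another, whereas here the whole chain leaves and a hydroxy remains. Among the measured compounds shown here, the three compounds therefore give no precedent for the size or direction of this step, and the expectation rests on the structural change alone.

For compound 4 in this assay the estimate is 3.1, with a range from 2.4 to 3.8, which would mean an expected step of a number 1.53 log units higher from compound 1 to compound 4 (beyond the scatter) from compound 1 to compound 4.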

Compound 4, partition coefficient: 1.42
The estimate for compound 4 lay 1.68 log units above the measured number; the measured number lies below the stated range.
By their numbers in this assay, from the lowest: compounds 4, 1, 2 and 3 (each within the scatter of the next).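

In this assay, taking the whole chain off the oxygen on the aromatic ring and leaving hydroxy gives a number 0.15 log units lower from compound 1 to compound 4 (within the scatter), while the same change with the other two chains gives a number 0.17 log units lower from compound 2 to compound 4 (within the scatter) and a number 0.19 log units lower from compound 3 to compound 4 (within the scatter). The earlier compounds shown here showed only that one amine could replace another at the far end of the chain, whereas these steps show that even the loss of the entire chain, amine included, cannot be told apart from the scatter at this position. Nothing measured here accounts for this result.

The compounds shown leave open whether a methyl on this oxygen, or a chain ending in a carboxylic acid, would also stay within the scatter of compound 4. As far as these compounds go, it also remains open how a shorter chain carrying the same pyrrolidin-1-yl group would read.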